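The source may hold more compounds than are shown below. What is called first, only, known or untested is meant among the compounds shown, and "the series" means these compounds.

Measured compounds:
compound 1, `Cn1ccc2c(Oc3ccc(NC(=O)c4nn(-c5ccc(Br)cc5)ccc4=O)cc3)ccnc21`, 16300 nM
compound 2, `Cn1ccc2c(Oc3ccc(NC(=O)c4nn(-c5ccc(Br)cc5)ccc4=O)cc3F)ccnc21`, 33600 nM
compound 3, `Cc1cc(=O)n(-c2ccccc2OC(F)(F)F)nc1C(=O)Nc1ccc(Oc2ncnc3c2ccn3C)cc1`, 27000 nM

In a functional assay on MCF7 cells (Homo sapiens) for cytotoxicity, read by MTT assay, with a stated time of 72 h (on this read-out lower numbers stand for stronger inhibition and higher numbers for weaker inhibition), compound 1 gives 16300 nM and compound 2 gives 33600 nM. The difference between them is fluoro in place of hydrogen on an aromatic carbon, and it made a 2.1-fold higher number from compound 1 to compound 2 (0.31 log units; beyond the scatter). Compound 3 has a different core from compound 1; the difference between the two cores is not broken down here. In this assay compound 3 gives 27000 nM, a value that sits within the scatter of compound 1 and of compound 2, so no order among the three can be drawn.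

Compound 4, `Cc1cc(=O)n(-c2ccccc2OC(F)(F)F)nc1C(=O)Nc1ccc(Oc2ncnc3c2ccn3C)c(F)c1`, is not yet measured. It differs from compound 3 by fluoro in place of hydrogen on an aromatic carbon, the same change as that from compound 1 to compound 2, with the same surroundings at the place. Since that earlier step was a 2.1-fold higher number from compound 1 to compound 2 (0.31 log units; beyond the scatter), the expected step from compound 3 to compound 4 in this assay is a 2.0-fold higher number from compound 3 to compound 4 (0.31 log units; beyond the scatter), a modest weakening of the same kind. The expected value for compound 4 is estimated as 55000 nM, with the estimate spanning from 25000 nM to 120000 nM.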

Compound 4, half-maximal inhibitory concentration: > 60000 nM
Compound 4 was reported as a limit; the forecaster's own chance of this, stated with the estimate: 20%; middle value at least 1.0-fold (0.03 log units) from the limit.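

In this assay compound 4 gives > 60000 nM, which is a limit of the assay and not a number. On this second core, fluoro in place of hydrogen on an aromatic carbon gave an at least 2.2-fold higher number from compound 3 to compound 4 (0.34 log units; beyond the scatter), so the weakening seen on the first core carried over in direction, and the step lies beyond the scatter on both cores. This shows that the direction held on the two cores shown, but it does not show that the size of the step carried over, and two cores make no rule for the whole series: the same change on two cores in this assay, a 2.1-fold higher number (0.31 log units; beyond the scatter) from compound 1 to compound 2 and an at least 2.2-fold higher number (0.34 log units; beyond the scatter) from compound 3 to compound 4; the limit leaves it open whether they differ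

The compounds shown leave open whether a different group on the same aromatic carbon, such as chloro, methoxy or an amine, would move the number in the same way as fluoro. They also leave open whether the change would keep its direction on a core carrying other substituents on the outer aromatic ring, such as a carboxylic acid or a longer chain.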